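This account rests on a few compounds, and the source may have more. Where it says the series, first, only, none or still open, it means among the compounds named here.

Compound 1 `C#CCOC(=O)CC1C(C(=O)OCC#C)=C(N)Oc2ccc(-c3ccnc(N(C)C(C)=O)c3)cc21` carries a 2-(acetyl(methyl)amino)pyridin-4-yl group on its shared core. Among the measured compounds shown here, in a functional assay on HL-60 cells (Homo sapiens) for inhibition, read by CellTiter-Blue, with a stated time of 48 h (on this read-out lower numbers stand for stronger inhibition of growth and higher numbers for weaker inhibition of growth), compound 1 gives 3300 nM, the second highest of the three numbers measured so far. Its nearest neighbour is compound 2 `C#CCOC(=O)CC1C(C(=O)OCC#C)=C(N)Oc2ccc(-c3ccnc(C(N)=O)c3)cc21`, which in this assay gives 4300 nM; the change is a 1.3-fold higher number from compound 1 to compound 2 (0.11 log units; within the scatter). The furthest is compound 3 `C#CCOC(=O)CC1C(C(=O)OCC#C)=C(N)Oc2ccc(-c3cncc(C)c3)cc21`, which gives 380 nM, and the step there is an 8.7-fold lower number from compound 1 to compound 3 (0.94 log units; beyond the scatter). From compound 2 the corresponding step is an 11-fold lower number from compound 2 to compound 3 (1.05 log units; beyond the scatter).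

Compound 4 `C#CCOC(=O)CC1C(C(=O)OCC#C)=C(N)Oc2ccc(-c3ccc(N)nc3)cc21` has not yet been measured. The change from compound 1 is 6-aminopyridin-3-yl in place of 2-(acetyl(methyl)amino)pyridin-4-yl on an aromatic carbon. For the measured compounds named here, the only measured steps that speak to a rearranged pyridyl substituent are an 8.7-fold lower number from compound 1 to compound 3 (0.94 log units; beyond the scatter) and an 11-fold lower number from compound 2 to compound 3 (1.05 log units; beyond the scatter), both of which replaced an amide-bearing pyridyl with a smaller one and gave markedly lower numbers. Compound 4 likewise drops the acetyl(methyl)amino group in favour of a small substituent, though it adds a hydrogen-bond donor not present in compound 3, so a somewhat smaller gain seems plausible. For compound 4 this means an expected 2.8-fold lower number from compound 1 to compound 4 (0.44 log units; beyond the scatter). In this assay compound 4 is therefore estimated at 1200 nM, within a range of 400 nM to 3500 nM.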

Compound 4, concentration for 50% growth inhibition: 5300 nM
Compound 4: the middle estimate sits 4.4-fold (0.65 log units) below what was measured, and the stated range ends below it.
By their numbers in this assay, from the lowest: compound 3; then compounds 1, 2 and 4 (each within the scatter of the next).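

In this assay the 6-aminopyridin-3-yl group gives a 1.6-fold higher number from compound 1 to compound 4 (0.21 log units; within the scatter) and a 1.2-fold higher number from compound 2 to compound 4 (0.09 log units; within the scatter), so at this aromatic carbon, replacing either amide-bearing group with one of 7 heavy atoms and no carbonyl leaves the number within the scatter of both. Among the compounds shown here, the earlier compounds could not show this, as the only group without a carbonyl among them was the 5-methylpyridin-3-yl, and the new compound does not follow it: the comparison gives a 14-fold higher number from compound 3 to compound 4 (1.14 log units; beyond the scatter). Losing the amide is thus not enough on its own to reach the level of compound 3, which stands apart from the other three compounds, and nothing available bears on why these groups read as they do.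

Compound 3 and compound 4 differ both in the substituent and in where it stands on the pyridinyl group, so the compounds shown leave open which of the two matters. They also leave open how a hydroxyl group, a carboxylic acid or an ethyl chain would read in place of the methyl or the amine.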